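Swapping a Benzyl Amine for a Trimethylphenyl Amine

The compounds below may be only part of what the source reports. "The series", "measured", "known", "first", "only" and "open" are said of these compounds alone.

Compound 1 `Cc1ccccc1Nc1nc(NCc2ccccc2)ncc1Cl`: > 100000 nM in a functional assay on Jurkat cells (Homo sapiens) for inhibition, read by CCK-8 assay, with a stated time of 48 h (on this read-out higher numbers stand for weaker inhibition of growth and lower numbers for stronger inhibition of growth), a limit of the assay.
Compound 2 `Cc1ccccc1Nc1nc(Nc2ccc(N3CCNCC3)cn2)ncc1Cl`: 7870 nM in this assay.
Compound 3 `CN1CCN(c2ccc(Nc3ncc(Cl)c(NCc4ccccc4)n3)nc2)CC1`: > 100000 nM in this assay, a limit of the assay.

Compound 3 sits at the limit of > 100000 nM in this assay, at which 2 of the 3 values shown sit, so no number is known for it, only that its inhibition of growth is weaker than the assay can resolve. Compound 4 `Cc1cc(C)c(Nc2nc(Nc3ccc(N4CCN(C)CC4)cn3)ncc2Cl)c(C)c1` has not yet been measured. It differs from compound 3 in one place: 2,4,6-trimethylphenyl in place of benzyl on a nitrogen on an aromatic ring. Going by the values given here, no measured pair carries the same change, so the size of the step is uncertain. Compound 2, which also carries an aromatic amine on the shared core, gives a number at 7870 nM. A step toward stronger inhibition of growth is therefore expected. Compound 4 is estimated at 6000 nM, between 1000 nM and 40000 nM, a step of an at least 16-fold lower number from compound 3 to compound 4 (1.22 log units; beyond the scatter).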

Compound 4, concentration for 50% growth inhibition: 7600 nM
For compound 4 the middle estimate is 1.3-fold (0.10 log units) below the measured one, and the stated range covers the measured number.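

In this assay compound 3 gives > 100000 nM as a limit of the assay. With 2,4,6-trimethylphenyl in place of benzyl on this nitrogen, the read-out falls to a measurable number (an at least 13-fold lower number from compound 3 to compound 4 (1.11 log units; beyond the scatter)), so the group here can decide whether any inhibition of growth is seen. On these data alone, the true size of the step stays unknown because its starting point is only a limit: the limit of > 100000 nM in this assay, at which 2 of the 4 values shown sit.

Still open, as far as these compounds go, is whether plain phenyl on this nitrogen would give the same result or the methyl groups are needed. A cyclohexyl group here would test whether an aromatic ring is required.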